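Compound 1 to compound 3: tert-butyl in place of ethoxy

The source may hold more compounds than are shown below. What is called first, only, known or untested is meant among the compounds shown, and "the series" means these compounds.

Measured so far in a functional assay on MGC-803 cells (Homo sapiens) for antiproliferative activity, read by MTT assay, with a stated time of 48 h; a lower number here means a stronger inhibitor, a higher number a weaker inhibitor
compound 1 `CCOc1ccc(NC(=O)Nc2cccc(CNc3nccnc3Cl)c2)cc1` gives 7240 nM
compound 2 `O=C(Nc1cccc(CNc2nccnc2Cl)c1)Nc1ccccc1F` gives 6440 nM

Within the data shown here, compound 1 stands level with compound 2, the only other compound measured. Compound 3 `CC(C)(C)c1ccc(NC(=O)Nc2cccc(CNc3nccnc3Cl)c2)cc1` remains unmeasured. Among the measured compounds shown here, it keeps the core of compound 1 and carries tert-butyl in place of ethoxy on an aromatic carbon, para to a large group tert-butyl in place of ethoxy on an aromatic carbon as the single change.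

For the measured compounds named here, one measured step bears on this change. It replaces 4-ethoxyphenyl with 2-fluorophenyl on an amide-type nitrogen and amounts to a 1.1-fold lower number from compound 1 to compound 2 (0.05 log units; within the scatter) within the scatter. Going by the values given here, no tert-butyl compound has been measured, so the evidence is thin. The estimated step in this assay is a 1.1-fold lower number from compound 1 to compound 3 (0.05 log units; within the scatter) and none beyond the scatter is expected. For compound 3 the expected value is 6500 nM with an estimated range from 2800 nM to 15000 nM as the working figure.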

Compound 3, half-maximal inhibitory concentration: 4820 nM
Beside the measured number, compound 3's estimate is 1.3-fold (0.13 log units) above it, within the range that was stated.
By their numbers in this assay, from the lowest: compounds 3, 2 and 1 (each within the scatter of the next).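

In this assay, tert-butyl in place of ethoxy on the aromatic carbon para to a large group gives a 1.5-fold lower number from compound 1 to compound 3 (0.18 log units; within the scatter). This position therefore accepts an all-carbon group with no hydrogen-bond acceptor, and with one more heavy atom than ethoxy, without a step beyond the scatter, so the oxygen of ethoxy is not needed to hold the number at this level in this pair. No measurement shown gives a reason for this step, and none can be offered from these data.

From the compounds shown here alone, whether an amine or a carboxylic acid at this position would move the number beyond the scatter stays open, as does the effect of a longer chain such as butoxy. The compounds shown also leave open whether any change on this aromatic ring can produce a step beyond the scatter.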